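The source may hold more compounds than are shown below. What is called first, only, known or untested is meant among the compounds shown, and "the series" means these compounds.

The measured compounds:

compound 1, `CCOC(=O)c1c(-c2cc(F)cc(OC)c2)[nH]c2cc(OC)ccc2c1=O` — > 22000 nM
compound 2, `CCOC(=O)c1c(-c2cccc(C)c2)[nH]c2cc(OC)ccc2c1=O` — > 22000 nM

In an ADME assay on HEK293 cells (Homo sapiens) for cytotoxicity, read by luminescence, with a stated time of 72 h (a higher number here means that more compound is needed for the effect, a lower number that less compound is needed), compound 1 gives > 22000 nM, which is a limit of the assay rather than a number. In this assay compound 2 gives > 22000 nM, again a limit of the assay. The step that the two limits leave unreadable from compound 1 to compound 2 therefore cannot be read, as both values sit at the same limit, (the limit of > 22000 nM in this assay, at which 2 of the 2 values shown sit). Compound 2 thus stands at that limit, with no measured number of its own.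

Compound 3, `CCOC(=O)c1c(-c2cccc(F)c2)[nH]c2cc(OC)ccc2c1=O`, differs from compound 2 in one place: fluoro in place of methyl on an aromatic carbon. For the measured compounds named here, no measured step speaks to this change, since the single step between the measured compounds is unreadable. The expectation for this assay is therefore no step beyond the usual scatter, with the result most likely again a limit. Compound 3 is estimated at 30000 nM, within a range of 15000 nM to 80000 nM. That estimate means the step that the limit leaves unreadable from compound 2 to compound 3 is expected.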

Compound 3, half-maximal effective concentration: > 22000 nM
Compound 3 ended at the assay's limit; the forecaster's own chance of this, stated with the estimate: 85%; the middle value does not contradict the limit.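

No step can be read between compound 1, compound 2 and compound 3, because each value is a limit and not a number: the limit of > 22000 nM in this assay, at which 3 of the 3 values shown sit.

Left open is the actual concentration each compound needs for the effect in this assay and whether these changes on the aromatic ring make any difference there.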